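The compounds below may be only part of what the source reports. "The series", "measured", "known", "first", "only" and "open" are said of these compounds alone.

Measured so far in an assay on isolated protein for inhibition of adenosine deaminase (Bos taurus), with a stated time of 5 min; a higher number here means a weaker inhibitor, a lower number a stronger inhibitor:

compound 1, `COC(=O)c1cccc(CC[C@H]([C@H](C)O)n2cnc3c(N)ncnc32)c1`: 2.2 nM
compound 2, `C[C@H](O)[C@@H](CCc1cccc(CO)c1)n1cnc2c(N)ncnc21`: 4.6 nM
compound 3, `C[C@H](O)[C@@H](CCc1cccc(C(=O)N(C)C)c1)n1cnc2c(N)ncnc21`: 1.8 nM

Compound 1 gives the second highest of the three numbers. Its nearest neighbour is compound 3, a 1.2-fold lower number from compound 1 to compound 3 (0.09 log units; within the scatter); its furthest is compound 2, a 2.1-fold higher number from compound 1 to compound 2 (0.32 log units; beyond the scatter). Between the other two, a 2.6-fold lower number from compound 2 to compound 3 (0.41 log units; beyond the scatter).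

Compound 4, `C[C@H](O)[C@@H](CCc1cccc(C(=O)N2CCCC2)c1)n1cnc2c(N)ncnc21`, is not yet measured. Relative to compound 1 the change is pyrrolidin-1-yl in place of methoxy on a carbonyl carbon, so the methoxycarbonyl becomes a (pyrrolidin-1-yl)carbonyl.

Among the measured compounds shown here, the one measured step that bears directly on this is the exchange at the same carbonyl carbon, dimethylamino in place of methoxy, going from compound 1 to compound 3, which stayed within the scatter. The step from compound 2 to compound 3 adds only that the dimethylcarbamoyl sits modestly below the hydroxymethyl. For the measured compounds named here, no measured step here moved more than modestly, and the closest parallel moved not at all beyond the scatter, so the expectation for compound 4 in this assay is a step within the scatter, if anything slightly downward, a 1.2-fold lower number from compound 1 to compound 4 (0.09 log units; within the scatter).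

Compound 4 is therefore estimated at 1.8 nM, with a range of 0.8 nM to 4.5 nM.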

Compound 4, inhibition constant: 2.2 nM
Compound 4: the middle estimate sits 1.2-fold (0.09 log units) below what was measured; measured number inside the range.
By their numbers in this assay, from the lowest: compounds 3, 1 and 4 (each within the scatter of the next); then compound 2.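

Working notes on the carbonyl carbon: in this assay, a ring on this carbon fits the same flat picture as the open dimethylamino, with pyrrolidin-1-yl in place of methoxy (no change at the digits printed from compound 1 to compound 4 (within the scatter)) and pyrrolidin-1-yl in place of dimethylamino (a 1.2-fold higher number from compound 3 to compound 4 (0.09 log units; within the scatter)). Against the hydroxymethyl, the (pyrrolidin-1-yl)carbonyl stays on the same side as the dimethylcarbamoyl (a 2.1-fold lower number from compound 2 to compound 4 (0.32 log units; beyond the scatter)), so among the compounds shown only compound 2 stands apart from the rest. Nothing available accounts for this lack of response at the carbonyl carbon.

Open, on these data alone, is whether the flat response extends to a piperidin-1-yl or morpholin-4-yl on this carbon, to an amide that keeps its amide hydrogen, or to the free carboxylic acid. Also open, as far as these compounds go, is how a longer chain in place of the ethylene link would read.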